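The source may hold more compounds than are shown below. What is called first, only, known or untested is meant among the compounds shown, and "the series" means these compounds.

Compound 1, `CC1(C)Oc2ccc(C(=O)Cc3ccccc3)cc2[C@@H](/N=C(\NC#N)Nc2ccc(Cl)cc2)[C@@H]1O`, in a functional assay (aorta) with Rattus norvegicus as the target; a higher number here means a weaker inhibitor, a lower number a stronger inhibitor: 6800 nM.
Compound 2, `CC1(C)Oc2ccc(S(=O)(=O)Nc3ccccc3)cc2[C@@H](/N=C(\NC#N)Nc2ccc(Cl)cc2)[C@@H]1O`, in this assay: 3300 nM.

For the measured compounds named here, compound 2 has the lowest number of the two, and the only measured step, a 2.1-fold lower number from compound 1 to compound 2 (0.31 log units; beyond the scatter), is modest. Compound 3, `CC1(C)Oc2ccc(C(=O)Nc3ccccc3)cc2[C@@H](/N=C(\NC#N)Nc2ccc(Cl)cc2)[C@@H]1O`, carries phenylcarbamoyl in place of phenylsulfamoyl on an aromatic carbon. Going by the values given here, that step swaps one linking group for another, which no measured pair shows, so the one known step offers only loose guidance. A small change, within or near the scatter, is expected: a 1.2-fold higher number from compound 2 to compound 3 (0.08 log units; within the scatter). Compound 3 is therefore estimated at 4000 nM, with a range from 1500 nM to 11000 nM.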

Compound 3, half-maximal inhibitory concentration: > 100000 nM
Compound 3: no number, only a limit; the forecaster's own chance of this, stated with the estimate: 5%; at least 25-fold (1.39 log units) between middle value and limit.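

In this assay, compound 3 gives only a limit of the assay, > 100000 nM, and no number. Sensitivity at this aromatic carbon to the linking group now shows itself: phenylcarbamoyl in place of phenylsulfamoyl gives an at least 30-fold higher number from compound 2 to compound 3 (1.48 log units; beyond the scatter), whereas the earlier pair differed only modestly. Compounds 1 and 3 both keep the carbonyl, yet anilino in place of benzyl gives an at least 14-fold higher number from compound 1 to compound 3 (1.16 log units; beyond the scatter).

From the compounds shown here alone, how much weaker compound 3 truly is stays unknown: the limit of > 100000 nM in this assay, at which 1 of the 3 values shown sits. Also open is whether a methyl group on the amide nitrogen, or a plain amine at this carbon, would bring the number back down.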